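The source may hold more compounds than are shown below. What is called first, only, known or untested is meant among the compounds shown, and "the series" means these compounds.

In a functional assay on HCT-116 cells (Homo sapiens) for antiproliferative activity, read by CellTiter-Glo, with a stated time of 72 h (on this read-out lower numbers stand for stronger inhibition and higher numbers for weaker inhibition), three compounds share one core and differ in a single ring substituent. Compound 1 `O=C(NO)c1ccc(/C=C/c2ccnc(-c3cc(F)ccc3O)c2)cc1`, carrying 5-fluoro-2-hydroxyphenyl, gives 2040 nM. Compound 3 `COc1ccc(-c2cc(/C=C/c3ccc(C(=O)NO)cc3)ccn2)cc1`, carrying 4-methoxyphenyl, gives 3560 nM, and a 1.7-fold higher number from compound 1 to compound 3 (0.24 log units; within the scatter) leaves the two values indistinguishable. Compound 2 `O=C(NO)c1ccc(/C=C/c2ccnc(-c3ccc(F)cc3)c2)cc1`, carrying 4-fluorophenyl, gives > 10000 nM, which is a limit of the assay and not a number.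

Compound 4 `Cc1ccc(-c2cc(/C=C/c3ccc(C(=O)NO)cc3)ccn2)c(F)c1` has 2-fluoro-4-methylphenyl in place of the 4-methoxyphenyl of compound 3, on an aromatic carbon next to the ring nitrogen: 2-fluoro-4-methylphenyl in place of 4-methoxyphenyl on an aromatic carbon. The closest guide is an at least 2.8-fold lower number from compound 2 to compound 3 (0.44 log units; beyond the scatter), with methoxy in place of fluoro. Also relevant is an at least 4.9-fold higher number from compound 1 to compound 2 (0.69 log units; beyond the scatter). Both steps lie beyond the scatter, so swapping this group can matter. Compound 4 loses the methoxy, as compound 2 does, but it is not the same group as in compound 2, so only part of that loss is expected. In this assay the expected result is a 1.4-fold higher number from compound 3 to compound 4 (0.15 log units; within the scatter), a small weakening at most, about the size of the scatter. For compound 4 the estimated value is 5000 nM, with an expected range from 2000 nM to 10000 nM.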

Compound 4, half-maximal inhibitory concentration: 800 nM
Estimate against measurement, compound 4: 6.3-fold (0.80 log units) above; the whole stated range lies above it.
By their numbers in this assay, from the lowest: compound 4; then compounds 1 and 3 (each within the scatter of the next). At a limit, above all of these: compound 2.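

In this assay, the ring on the aromatic carbon next to the ring nitrogen can do better than the earlier substituents suggested, with a 4.5-fold lower number from compound 3 to compound 4 (0.65 log units; beyond the scatter) and a 2.6-fold lower number from compound 1 to compound 4 (0.41 log units; beyond the scatter). Compound 4 achieves this without the oxygen carried by the methoxy of compound 3 or the hydroxy of compound 1, so an oxygen on this ring is not required. Losing that oxygen does not by itself bring the gain, since compound 2 also lacks it and its value is a limit of the assay and not a number, which makes an at least 12-fold lower number from compound 2 to compound 4 (1.09 log units; beyond the scatter) a step with only one bound: the limit of > 10000 nM in this assay, at which 1 of the 4 values shown sits.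

The compounds shown do not separate the 2-fluoro from the 4-methyl part of the new ring, so which of them carries the gain stays open. From the compounds shown here alone, whether an amine, a carboxylic acid or a longer chain in place of the methyl would keep this activity also remains unknown.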